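The source may report more compounds than this note shows. Statements on the series, on what has been measured and on what is new or still open speak of the compounds shown alone.

Of the compounds shown here, three of a shared core have been measured in a functional assay on HCC827 cells (Homo sapiens) for antiproliferative activity, read by MTT assay, with a stated time of 72 h; on this read-out lower numbers stand for stronger inhibition and higher numbers for weaker inhibition. Compound 1 `CN1CCN(c2ccc(Nc3ncc4nc(SCc5cccnc5)n(C5CCOCC5)c4n3)cc2)CC1` gives 500 nM. Compound 2 `CN1CCN(c2ccc(Nc3ncc4nc(SCc5cccnc5)n(C5CC5)c4n3)cc2)CC1` gives 8830 nM, and compound 3 `CN1CCN(c2ccc(Nc3ncc4nc([S+]([O-])c5ccccc5)n(C5CCOCC5)c4n3)cc2)CC1` gives 411 nM.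

The change from compound 1 to compound 2 is cyclopropyl in place of oxan-4-yl on an aromatic nitrogen and it produced an 18-fold higher number from compound 1 to compound 2 (1.25 log units; beyond the scatter). The core of compound 3 differs from that of compound 1 by a group of 8 heavy atoms (6 carbon, 1 oxygen, 1 sulfur; one six-membered aromatic ring of carbon only) in place of a group of 8 heavy atoms (6 carbon, 1 nitrogen, 1 sulfur; one six-membered aromatic ring with 1 hetero atom), on an aromatic carbon, a change that produced a 1.2-fold lower number from compound 1 to compound 3 (0.09 log units; within the scatter).

Compound 4 `CN1CCN(c2ccc(Nc3ncc4nc([S+]([O-])c5ccccc5)n(C5CC5)c4n3)cc2)CC1` has not yet been measured in this assay . Its change from compound 3 is cyclopropyl in place of oxan-4-yl on an aromatic nitrogen. This is the same kind of change as that from compound 1 to compound 2, though the surroundings differ: in compound 1 the ring atom next to the site bears a ((pyridin-3-yl)methyl)sulfanyl group, while in compound 3 it bears a group of 8 heavy atoms. Because an 18-fold higher number from compound 1 to compound 2 (1.25 log units; beyond the scatter) was large, a step of about an 18-fold higher number from compound 3 to compound 4 (1.26 log units; beyond the scatter) is expected from compound 3 to compound 4 in this assay . On that basis compound 4 is estimated at 7400 nM, within a range from 2500 nM to 20000 nM.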

Compound 4, half-maximal inhibitory concentration: 1630 nM
Beside the measured number, compound 4's estimate is 4.5-fold (0.66 log units) above it, outside the stated range (below it).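

Putting cyclopropyl in place of oxan-4-yl gave a 4.0-fold higher number from compound 3 to compound 4 (0.60 log units; beyond the scatter) in this assay, so the direction of the step seen on the core of compound 1 holds, but its size does not carry over: the same change on two cores in this assay, an 18-fold higher number (1.25 log units; beyond the scatter) from compound 1 to compound 2 and a 4.0-fold higher number (0.60 log units; beyond the scatter) from compound 3 to compound 4, 4.5-fold (0.65 log units) apart, beyond the scatter of two such steps

Seen from the other side, exchanging the ((pyridin-3-yl)methyl)sulfanyl group for the group of 8 heavy atoms with its carbon-only aromatic ring gave a 5.4-fold lower number from compound 2 to compound 4 (0.73 log units; beyond the scatter), while the same exchange with oxan-4-yl in place stayed within the scatter, so the two changes do not simply add up: the same change on two cores in this assay, a 1.2-fold lower number (0.09 log units; within the scatter) from compound 1 to compound 3 and a 5.4-fold lower number (0.73 log units; beyond the scatter) from compound 2 to compound 4, 4.5-fold (0.65 log units) apart, beyond the scatter of two such steps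

These four compounds show that dependence for this one pair of groups only; they do not show what lies behind it, or how large the step would be on any other core.

Still open, as far as these compounds go, is how other groups on that aromatic nitrogen, such as cyclopentyl or an isopropyl chain, would fare with each of the two sulfur-bearing groups. Also open, from the compounds shown here alone, is whether piperidin-4-yl, a ring amine of the same size as oxan-4-yl, would behave like oxan-4-yl.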